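Lengthening the Fatty Chain of an Amide Antiproliferative

The compounds below may be only part of what the source reports. "The series", "measured", "known", "first", "only" and "open" are said of these compounds alone.

Measured so far:
compound 1, `CCCCCCCCCCCCCCCCCC(=O)N1CCOCC1`, gives 41.1 ug/mL
compound 2, `CCCCCCCCCCCCCCCC(=O)N1CCCC1`, gives 4.7 ug/mL

In a functional assay on PC-3 cells (Homo sapiens) for antiproliferative activity, read by sulforhodamine B assay, with a stated time of 48 h (on this read-out lower numbers stand for stronger inhibition of growth and higher numbers for weaker inhibition of growth), compound 2 stands lowest of the two numbers, and compound 1 gives a number beyond the scatter above it; the two differ in more than one place, so nothing is tied to a single change. Compound 3, `CCCCCCCCCCCCCCCCCC(=O)N1CCCC1`, differs from compound 2 by ethyl in place of hydrogen on a saturated chain carbon, ten or more bonds along the chain from a carbonyl carbon. Going by the values given here, with no measured step of this kind to lean on, a modest move is expected, most likely toward weaker growth inhibition, with a 1.7-fold higher number from compound 2 to compound 3 (0.23 log units; within the scatter). Compound 3 is therefore estimated at 8 ug/mL, within 3 ug/mL to 25 ug/mL.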

Compound 3, concentration for 50% growth inhibition: 9.4 ug/mL
Estimate against measurement, compound 3: 1.2-fold (0.07 log units) below; measured number inside the range.
By their numbers in this assay, from the lowest: compounds 2 and 3 (each within the scatter of the next); then compound 1.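

In this assay, ethyl in place of hydrogen on a saturated chain carbon, ten or more bonds along the chain from a carbonyl carbon, gives a 2.0-fold higher number from compound 2 to compound 3 (0.30 log units; within the scatter), so this change stays within repeat scatter. Compound 3 also makes the amide end readable on its own: pyrrolidin-1-yl in place of morpholin-4-yl on a carbonyl carbon gives a 4.4-fold lower number from compound 1 to compound 3 (0.64 log units; beyond the scatter). Nothing available explains this difference.

Open, on these data alone, is whether a much longer chain on the pyrrolidin-1-yl amide would also stay within the scatter. As far as these compounds go, a carboxylic acid or an amine at the far end of the chain also remains untested here.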